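Adding a Methyl to the Ketone Side Chain

A few compounds are considered here, and "the series" means these few. Any claim that something is new, unique, unknown or untested is made for them only; others in the source may bear on it.

Compound 3 `COc1cc(C(=O)O)ccc1OCCCCOc1ccc(C(C)=O)c(O)c1C` and compound 4 `CCC(=O)c1ccc(OCCCCOc2ccc(C(=O)O)cc2OC)c(C)c1O` share a core, and compound 4 differs only by methyl in place of hydrogen on a saturated chain carbon bound to a carbonyl carbon. The same kind of change links compound 2 `CCC(=O)c1ccc(OCCCCOc2cccc(C(=O)O)c2C)c(C)c1O` to compound 1 `Cc1c(OCCCCOc2ccc(C(=O)C(C)C)c(O)c2C)cccc1C(=O)O`, though there it reads (methyl in place of hydrogen on a saturated chain carbon bound to a carbonyl carbon and a saturated chain carbon), so the surroundings of the place differ. The difference between the two cores is not broken down here. In an assay on HEK293 cells for positive allosteric modulation of metabotropic glutamate receptor 2 (Rattus norvegicus), read by thallium flux, with a stated time of 2.5 min (a higher number here means that more compound is needed for the effect, a lower number that less compound is needed), compound 3 gives 161 nM, compound 2 gives 62 nM, and compound 1 gives 149 nM, a step of a 2.4-fold higher number from compound 2 to compound 1 (0.38 log units; beyond the scatter). Because compound 2 with its propanoyl group gives 62 nM, while the earlier methyl addition cost a 2.4-fold higher number from compound 2 to compound 1 (0.38 log units; beyond the scatter), the step from compound 3 to compound 4 is expected to be small, about a 1.5-fold lower number from compound 3 to compound 4 (0.17 log units; within the scatter). Compound 4 is therefore estimated at 110 nM, between 45 nM and 270 nM.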

Compound 4, half-maximal effective concentration: 114 nM
The estimate for compound 4 lay 1.0-fold (0.02 log units) below the measured number; measured number inside the range.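

In this assay, methyl in place of hydrogen on the ketone side chain of compound 3 gives only a small step (a 1.4-fold lower number from compound 3 to compound 4 (0.15 log units; within the scatter)). The same change does not carry over with the same size from one core to the other: the same change on two cores in this assay, a 2.4-fold higher number (0.38 log units; beyond the scatter) from compound 2 to compound 1 and a 1.4-fold lower number (0.15 log units; within the scatter) from compound 3 to compound 4, 3.4-fold (0.53 log units) apart, beyond the scatter of two such steps. Going by these compounds alone, with only two pairs, and with different surroundings around the place of change, these steps do not show whether the core or those surroundings set the gap.

The compounds shown leave open what a longer chain or a cyclopropyl group would do at this place. Within the data shown here, they also leave open whether a further methyl on the core of compound 4 would give a step like the one to compound 1.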